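This account rests on a few compounds, and the source may have more. Where it says the series, first, only, none or still open, it means among the compounds named here.

Measured so far in an assay on HEK293 cells for agonist activity at Toll-like receptor 8 (Homo sapiens), read by spectrophotometry; on this read-out lower numbers stand for an effect already at smaller amounts and higher numbers for an effect only at larger amounts of compound:
compound 1 `CCCCNc1nc(N)nc(C)c1CCCN1CCCCCC1` gives 178 nM
compound 2 `CCCCNc1nc(N)nc(C)c1CCCN(CC)CC` gives 254 nM

Compound 2 and compound 1 stand level within the scatter: the step of a 1.4-fold higher number from compound 1 to compound 2 (0.15 log units; within the scatter) separates them, and no more. Compound 3 `CCCCNc1nc(N)nc(C)c1CCCn1cncn1` has not yet been measured. It differs from compound 2 by 1H-1,2,4-triazol-1-yl in place of diethylamino on a saturated chain carbon, three bonds along the chain from an aromatic carbon. Going by the values given here, the only measured step, a 1.4-fold higher number from compound 1 to compound 2 (0.15 log units; within the scatter), exchanges one amino group for another at the same chain position and does not speak to the exchange of an amino group for the entering 1H-1,2,4-triazol-1-yl ring; no measured step covers this change. With that gap in the series, a shift to a higher number in this assay is expected for compound 3, held with wide uncertainty, as a 2.8-fold higher number from compound 2 to compound 3 (0.44 log units; beyond the scatter). The estimate for compound 3 in this assay is 700 nM, expected within a range from 200 nM to 3000 nM.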

Compound 3, half-maximal effective concentration: 1050 nM
For compound 3 the middle estimate is 1.5-fold (0.18 log units) below the measured one; measured number inside the range.
By their numbers in this assay, from the lowest: compounds 1 and 2 (each within the scatter of the next); then compound 3.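

In this assay, this chain position proves sensitive to the kind of group it carries: the earlier exchange of one amino group for another stayed within the scatter, while 1H-1,2,4-triazol-1-yl in place of diethylamino, with 5 heavy atoms leaving and 5 entering, gives a 4.1-fold higher number from compound 2 to compound 3 (0.62 log units; beyond the scatter). The comparison with azepan-1-yl points the same way, with a 5.9-fold higher number from compound 1 to compound 3 (0.77 log units; beyond the scatter), so among these three compounds both amino groups stand at lower numbers than the triazole. No supporting data bear on why the number rises.

Still open, on these data alone, is whether the higher number goes with the aromatic ring itself or with the loss of the amino group. An imidazol-1-yl or morpholin-4-yl group at the same chain position, or a longer chain carrying the triazole, would help separate these readings.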